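Compound 2 to compound 4: one change on the ring nitrogen

The source may hold more compounds than are shown below. What is called first, only, known or untested is meant among the compounds shown, and "the series" means these compounds.

Measured so far:
compound 1, `O=C(NCCCCc1ccccc1)n1c(=O)oc2ccncc21`, gives 6 nM
compound 2, `CC(C)N1CCC(c2ccc3c(c2)oc(=O)n3C(=O)NCCCCc2ccccc2)CC1`, gives 94 nM
compound 3, `CCCCCNC(=O)n1c(=O)oc2cc(C3CCN(C)CC3)ccc21`, gives 396 nM

All three numbers come from an assay on HEK293 cells for inhibition of acid ceramidase (Homo sapiens), read by fluorescence, with stated times of 10 min and 3 h; on this read-out lower numbers stand for stronger inhibition and higher numbers for weaker inhibition. Compound 2 holds the second highest of the three numbers. Its nearest neighbour is compound 3, which gives 396 nM, a difference beyond the usual scatter, and its furthest is compound 1, which gives 6 nM, also a difference beyond the scatter.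

The unmeasured compound 4, `CC(=O)N1CCC(c2ccc3c(c2)oc(=O)n3C(=O)NCCCCc2ccccc2)CC1`, differs from compound 2 in one place: acetyl in place of isopropyl on an amine nitrogen in a ring. For the measured compounds named here, no pair of measured compounds shows this exact change, so the direction of the step has to be read from the structures alone. Compound 1, which carries no group at all on the shared core, gives the lowest number, while the two compounds that carry a substituted piperidin-4-yl group both give higher numbers; how that group is substituted is not separated from the other changes between compound 2 and compound 3.

On this basis the step from compound 2 to compound 4 is expected to be small, a 1.3-fold lower number from compound 2 to compound 4 (0.13 log units; within the scatter), not clearly beyond the scatter in either direction. Compound 4 is therefore estimated at 70 nM, within a range from 18 nM to 280 nM.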

Compound 4, half-maximal inhibitory concentration: 64 nM
Compound 4: the middle estimate sits 1.1-fold (0.04 log units) above what was measured; the measured number falls inside the stated range.
By their numbers in this assay, from the lowest: compound 1; then compounds 4 and 2 (each within the scatter of the next); then compound 3.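

In this assay, for the compounds shown here, compounds 2 and 4 give the first direct reading of this ring nitrogen, with acetyl in place of isopropyl and the rest of the molecule unchanged: a 1.5-fold lower number from compound 2 to compound 4 (0.17 log units; within the scatter). Until now, the substitution on this nitrogen could not be separated from the other changes between compound 2 and compound 3, whereas this pair isolates it and shows that a group with a carbonyl and a hydrogen-bond acceptor can replace an all-carbon group of the same heavy-atom count without a step beyond the scatter. No measurement at hand explains this result or shows what either group does at this nitrogen.

As far as these compounds go, it remains open whether a bare ring nitrogen carrying only hydrogen, a longer acyl chain such as hexanoyl, or a chain ending in a carboxylic acid would also stay within the scatter of compound 2. From the compounds shown here alone, it is equally open whether acetyl would read the same way on compound 3, which has a pentyl chain and a methyl group on this nitrogen.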